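A few compounds are considered here, and "the series" means these few. Any claim that something is new, unique, unknown or untested is made for them only; others in the source may bear on it.

Of the compounds shown here, three that share one core have been tested in an ADME assay on HepG2 cells (Homo sapiens) for cytotoxicity, read by luminescence, CellTiter-Glo and ATP content, with a stated time of 72 h; on this read-out lower numbers stand for an effect already at smaller amounts and higher numbers for an effect only at larger amounts of compound. Compound 1 `c1ccc(-c2ccc3c(NCCCNCc4ccco4)ccnc3c2)cc1` gives 5920 nM. Compound 2 `Fc1ccc(-c2ccc3c(NCCCNCc4ccco4)ccnc3c2)cc1`, which carries fluoro in place of hydrogen on an aromatic carbon, gives 7760 nM; the step is a 1.3-fold higher number from compound 1 to compound 2 (0.12 log units; within the scatter). Compound 3 `Fc1ccc(Oc2ccc3c(NCCCNCc4ccco4)ccnc3c2)cc1` gives 16000 nM in this assay, the highest of the three numbers: the steps are a 2.7-fold higher number from compound 1 to compound 3 (0.43 log units; beyond the scatter) and a 2.1-fold higher number from compound 2 to compound 3 (0.31 log units; beyond the scatter).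

Compound 4 `COc1ccc(Oc2ccc3c(NCCCNCc4ccco4)ccnc3c2)cc1` has not been measured in this assay. It differs from compound 3 in one place: methoxy in place of fluoro on an aromatic carbon. Within the data shown here, of the measured steps, only the one from compound 1 to compound 2 touches the same position, and that step stayed within the scatter. The two steps ending at compound 3 concern another part of the molecule and only show how modest the changes seen so far have been. The step of no change at the digits printed from compound 3 to compound 4 (within the scatter) is therefore expected to stay within the scatter. Compound 4 is expected to give about 16000 nM in this assay, with a range from 8000 nM to 32000 nM.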

Compound 4, half-maximal effective concentration: 5300 nM
Compound 4: the middle estimate sits 3.0-fold (0.48 log units) above what was measured, outside the stated range (below it).
By their numbers in this assay, from the lowest: compounds 4, 1 and 2 (each within the scatter of the next); then compound 3.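

In this assay, among these compounds, the earlier compounds showed this position only through a change of hydrogen to fluoro on the phenyl compounds, and that step stayed within the scatter. Methoxy in place of fluoro on the phenoxy compounds (a 3.0-fold lower number from compound 3 to compound 4 (0.48 log units; beyond the scatter)) shows that the group at this position can move the number beyond the scatter. Compound 4 also stays within the scatter of both phenyl compounds (a 1.5-fold lower number from compound 2 to compound 4 (0.17 log units; within the scatter); a 1.1-fold lower number from compound 1 to compound 4 (0.05 log units; within the scatter)), so a phenoxy link alone does not go with a higher number, and no measurement at hand explains the difference between fluoro and methoxy.

Going by these compounds, it remains open whether the higher number of compound 3 is specific to fluoro, which a plain phenoxy, a chloro or an amine at this position would help to test. On these data alone, it also remains open whether methoxy in place of fluoro would act the same way on the phenyl compounds.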